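A few compounds are considered here, and "the series" means these few. Any claim that something is new, unique, unknown or untested is made for them only; others in the source may bear on it.

Measured in an ADME assay on Vero cells (Chlorocebus sabaeus) for cytotoxicity, read by MTT assay, with a stated time of 72 h; a lower number here means that less compound is tolerated, a higher number that more compound is tolerated:
compound 1 `COC(=O)CN1CCN(c2c(F)cc3c(=O)c(C(=O)O)cn(C4CC4)c3c2OC)CC1C` — 500 ug/mL
compound 2 `COc1c(N2CCN(C/C(C)=N/NC(N)=O)C(C)C2)c(F)cc2c(=O)c(C(=O)O)cn(C3CC3)c12` — 500 ug/mL

Compound 2 stands level with compound 1 in this assay; the step of no change at the digits printed from compound 1 to compound 2 (within the scatter) is within the scatter, even though a group of 7 heavy atoms (3 carbon, 3 nitrogen, 1 oxygen; no ring) replaced a group of 4 heavy atoms (2 carbon, 2 oxygen; no ring) on a saturated chain carbon bound to an amine nitrogen in a ring.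

Compound 3 `COc1c(N2CCN(CC/C(C)=N/NC(N)=O)C(C)C2)c(F)cc2c(=O)c(C(=O)O)cn(C3CC3)c12` is not yet measured in this assay. Its difference from compound 2: a group of 8 heavy atoms (4 carbon, 3 nitrogen, 1 oxygen; no ring) in place of a group of 7 heavy atoms (3 carbon, 3 nitrogen, 1 oxygen; no ring), on a saturated chain carbon bound to an amine nitrogen in a ring. Among the measured compounds shown here, the only measured step that bears on this position is no change at the digits printed from compound 1 to compound 2 (within the scatter), which left this assay unchanged despite a larger exchange of atoms at the same place. Nothing in the measured pair points to a shift in either direction. The expected step of no change at the digits printed from compound 2 to compound 3 (within the scatter) is therefore none beyond the scatter. Compound 3 is estimated to give 500 ug/mL in this assay, with a range from 250 ug/mL to 1000 ug/mL.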

Compound 3, half-maximal cytotoxic concentration: 31.3 ug/mL
For compound 3 the middle estimate is 16-fold (1.20 log units) above the measured one; measured number outside the range, below it.
By their numbers in this assay, from the lowest: compound 3; then compounds 1 and 2 (each within the scatter of the next).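

In this assay, the place on a saturated chain carbon bound to an amine nitrogen in a ring turns out to be sensitive to a small exchange: the group of 8 heavy atoms in place of the group of 7 heavy atoms gives a 16-fold lower number from compound 2 to compound 3 (1.20 log units; beyond the scatter), with the counted hydrogen-bond donors, hydrogen-bond acceptors and net charge the same in both groups. The same group set against the group of 4 heavy atoms gives a 16-fold lower number from compound 1 to compound 3 (1.20 log units; beyond the scatter), so the level shared by the two earlier compounds did not hold for every group at this place. No measurement in hand bears on what lies behind this drop.

Open, as far as these compounds go, is how a longer chain or a carboxylic acid at this place would read in this assay. A single step beyond the scatter sets no trend with chain size.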